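The compounds below may be only part of what the source reports. "The series", "measured", "known", "first", "only" and "open" are said of these compounds alone.

Among the compounds with values here, in a functional assay on cells (Platelet, Homo sapiens) for inhibition (on this read-out higher numbers stand for weaker inhibition and lower numbers for stronger inhibition), compound 3 `CCNC(=O)c1ccc(-c2nn(Cc3ccccc3)c3ccccc23)cc1` gives 5640 nM, the only actual number so far. Compound 1 `CCCOC(=O)c1ccc(-c2nn(Cc3ccccc3)c3ccccc23)cc1` reads > 10000 nM, which is a limit of the assay. Compound 2 `CC(C)OC(=O)c1ccc(-c2nn(Cc3ccccc3)c3ccccc23)cc1` reads > 10000 nM, also a limit. Next comes compound 4 `OCc1ccc(-c2nn(Cc3ccccc3)c3ccccc23)cc1`, with hydroxymethyl in place of ethylcarbamoyl on an aromatic carbon, para to a large group: hydroxymethyl in place of ethylcarbamoyl on an aromatic carbon. Within the data shown here, no measured step covers this change. The nearest are the exchanges on the carbonyl carbon, an at least 1.7-fold lower number from compound 1 to compound 3 (0.24 log units; that floor lies within the scatter) and an at least 1.7-fold lower number from compound 2 to compound 3 (0.24 log units; that floor lies within the scatter), and neither gives a firm size or direction. On that basis no step beyond the scatter is expected, with the estimated step of a 1.1-fold higher number from compound 3 to compound 4 (0.03 log units; within the scatter). The estimate for compound 4 is 6000 nM, with an expected range of 2000 nM to 15000 nM.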

Compound 4, half-maximal inhibitory concentration: > 10000 nM
Compound 4: no number, only a limit (the forecaster's own chance of this, stated with the estimate: 35%); at least 1.6-fold (0.22 log units) between middle value and limit.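

In this assay, hydroxymethyl in place of ethylcarbamoyl on the aromatic carbon gives an at least 1.7-fold higher number from compound 3 to compound 4 (0.24 log units; that floor lies within the scatter). Within the data shown here, this first change away from a carbonyl-bearing group yields no gain, and compound 3 remains the only compound with an actual number. The steps from compound 1 and compound 2 to compound 4 cannot be read, and the series now rests mostly on one ceiling: the limit of > 10000 nM in this assay, at which 3 of the 4 values shown sit.

On these data alone, how far compound 4 lies past its limit stays open, so any real loss remains unsized. Also open, as far as these compounds go, is whether a carboxylic acid or a propylcarbamoyl group at this position would give a number.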